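Chloro in place of methoxy: notes toward compound 4

This account rests on a few compounds, and the source may have more. Where it says the series, first, only, none or still open, it means among the compounds named here.

In a functional assay on the whole organism (strain Wistar) for inhibition, with Rattus norvegicus as the target, read by paw edema, with stated times of 30 min and 2.5 h, at a dose of 20 mg/kg by the intraperitoneal route (on this read-out lower numbers stand for less inhibition and higher numbers for more inhibition at the one dose given (going by the name of the read-out)), compound 1 `CCc1nnc2sc(-c3c[nH]nc3-c3ccc(Cl)cc3)nn12` gives 56.9%, compound 2 `CCCc1nnc2sc(-c3c[nH]nc3-c3ccc(F)cc3)nn12` gives 12% and compound 3 `CCCc1nnc2sc(-c3c[nH]nc3-c3ccc(OC)cc3)nn12` gives 13.5%. Compound 3 stands second highest of the three; its nearest neighbour is compound 2, within the scatter, while compound 1 lies beyond the scatter above it. Compound 4 `CCCc1nnc2sc(-c3c[nH]nc3-c3ccc(Cl)cc3)nn12` differs from compound 3 in one place: chloro in place of methoxy on an aromatic carbon. For the measured compounds named here, the only measured step at that position is a number 1.5 percentage points higher from compound 2 to compound 3 (within the scatter), which stayed inside the scatter. Compound 1 also carries chloro, but its chain differs as well, so its value of 56.9% only hints that chloro may sit higher. An upward step is therefore expected for compound 4, a number 18.5 percentage points higher from compound 3 to compound 4 (beyond the scatter), with wide uncertainty. Compound 4 is estimated at 32%, between 10% and 60%.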

Compound 4, a percentage reported as inhibition, in the whole organism at one dose (the size of the read-out at that dose, not a potency): 64.7%
Compound 4: the middle estimate sits 32.7 percentage points below what was measured; measured number above the stated range.
By their numbers in this assay, from the lowest: compounds 2 and 3 (each within the scatter of the next); then compounds 1 and 4 (each within the scatter of the next).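

In this assay, for the compounds shown here, this position proves sensitive to the group it carries, and chloro stands apart from both methoxy (a number 51.2 percentage points higher from compound 3 to compound 4 (beyond the scatter)) and fluoro (a number 52.7 percentage points higher from compound 2 to compound 4 (beyond the scatter)), which the earlier compounds, all with a propyl chain, could not show. With chloro in place, the chain change reads differently (a number 7.8 percentage points higher from compound 1 to compound 4 (within the scatter)), so methyl in place of hydrogen on the chain does not separate these two compounds. Nothing at hand speaks to the reason for the jump at the 4-chlorophenyl group.

As far as these compounds go, whether bromo or a nitrile at this position would read like chloro or like fluoro stays open. So does whether a butyl chain would keep the value of compound 4 (64.7%).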